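The source may hold more compounds than are shown below. What is called first, only, known or untested is meant among the compounds shown, and "the series" means these compounds.

Measured compounds in a functional assay on the whole organism (artery, strain albino) with Rattus norvegicus as the target, with a stated time of 180 min, at a dose of 10 mg/kg by the oral route; a higher number here means more inhibition at the dose given (going by the name of the read-out), a lower number less inhibition:

Compound 1 `CC1=C(C(=O)Nc2ccc(Br)cc2)C(c2ccc(Cl)cc2Cl)N=C(SCc2cccc(Cl)c2)N1` gives 11.9%.
Compound 2 `CC1=C(C(=O)Nc2ccc(Br)cc2)C(c2ccc(Cl)cc2Cl)N=C(SCc2ccc(Cl)cc2)N1` gives 23.2%.
Compound 3 `CC1=C(C(=O)Nc2ccc([N+](=O)[O-])cc2)C(c2ccc(Br)cc2)N=C(SCc2cccc(Cl)c2)N1` gives 9.3%.

Compound 4 `CC1=C(C(=O)Nc2ccc([N+](=O)[O-])cc2)C(c2ccc(Br)cc2)N=C(SCc2ccc(Cl)cc2)N1` is not yet measured in this assay.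

Compounds 1 and 2 differ by one change, (4-chlorophenyl in place of 3-chlorophenyl on a saturated chain carbon bound to a sulfur), and the step that goes with it is a number 11.3 percentage points higher from compound 1 to compound 2 (beyond the scatter). Compounds 3 and 4 differ by 4-chlorophenyl in place of 3-chlorophenyl on a saturated chain carbon bound to a sulfur, which is the same change at the same place. How the cores of compound 3 and compound 1 differ is not broken down here; their values in this assay lie within the scatter of one another, so nothing is made of that gap. Compound 2 stands beyond the scatter above compound 3.

Within the data shown here, only one measured pair carries this change, so the expectation rests on a single step. Compound 4 is expected to sit above compound 3 by a number 10.7 percentage points higher from compound 3 to compound 4 (beyond the scatter) because the same change gave a number 11.3 percentage points higher from compound 1 to compound 2 (beyond the scatter). The estimate for compound 4 in this assay is 20%, with a likely range from 8% to 32%.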

Compound 4, a percentage reported as inhibition, in the whole organism at one dose (the size of the read-out at that dose, not a potency): 19.1%
Compound 4: the middle estimate sits 0.9 percentage points above what was measured; low and high end bracket the measured number.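

In this assay, 4-chlorophenyl in place of 3-chlorophenyl on a saturated chain carbon bound to a sulfur goes with a number 9.8 percentage points higher from compound 3 to compound 4 (within the scatter). Read beside the earlier step, the change carries from one core to the other with a step of similar size, although only the earlier step clears the scatter: the same change on two cores in this assay, a number 11.3 percentage points higher (beyond the scatter) from compound 1 to compound 2 and a number 9.8 percentage points higher (within the scatter) from compound 3 to compound 4, 1.5 percentage points apart, within the scatter of two such steps This shows agreement across two cores only; it does not establish a general rule for the series, and as a single-dose read-out it says nothing about potency.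

The compounds shown leave open whether a step of this size would appear on other cores, or with other groups on the sulfur, such as an unsubstituted benzyl or a longer alkyl chain ending in an amine. Also open, on these data alone, is whether the step persists at other doses or times in this assay.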